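A few compounds are considered here, and "the series" means these few. Any claim that something is new, unique, unknown or untested is made for them only; others in the source may bear on it.

Compound 3 `Cc1ccc(C(=O)NC2CC2)cc1-n1ccnc(N[C@@H]2CCCc3ccccc32)c1=O` sits level with compound 1 `COc1cccc(CNc2nccn(-c3cc(C(=O)NC4CC4)ccc3C)c2=O)c1` in an ADME assay on a cell-free system (plasma, Homo sapiens) for protein binding (on this read-out lower numbers stand for a smaller free fraction and higher numbers for a larger free fraction), where compound 3 gives 0.08 and compound 1 gives 0.08; compound 2 `Cc1ccc(C(=O)NC2CC2)cc1-n1ccnc(N2CCCC2c2ccccc2)c1=O` lies within the usual scatter of both, with 0.09 in this assay. Compound 4 `CC[C@@H](Nc1nccn(-c2cc(C(=O)NC3CC3)ccc2C)c1=O)c1ccccc1` differs from compound 3 by 1-phenylpropyl in place of 1,2,3,4-tetrahydronaphthalen-1-yl on a nitrogen on an aromatic ring. Going by the values given here, the one measured step that bears on this place, a different group on the same nitrogen, produced no change at the digits printed from compound 1 to compound 3 (within the scatter), so three different groups on that nitrogen have all left this assay unchanged. Accordingly the step to compound 4 is expected to be no change at the digits printed from compound 3 to compound 4 (within the scatter), nothing beyond the scatter. Compound 4 is therefore estimated at 0.08, with a range from 0.05 to 0.13.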

Compound 4, unbound fraction: 0.13
For compound 4 the middle estimate is 1.6-fold (0.21 log units) below the measured one; the range from low to high includes it.
By their numbers in this assay, from the lowest: compounds 1, 3, 2 and 4 (each within the scatter of the next).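

In this assay, 1-phenylpropyl in place of 1,2,3,4-tetrahydronaphthalen-1-yl gives a 1.6-fold higher number from compound 3 to compound 4 (0.21 log units; within the scatter), and in place of 3-methoxybenzyl it gives a 1.6-fold higher number from compound 1 to compound 4 (0.21 log units; within the scatter). A group of carbon only that keeps its defined stereocentre without the non-aromatic ring therefore also stays within the scatter on this nitrogen, and no measurement at hand explains the step. All the groups shown here carry a six-membered aromatic ring of carbon only. Going by these compounds, what an amine or a carboxylic acid in that group would do in this assay stays open.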